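The compounds below may be only part of what the source reports. "The series", "measured", "known", "first", "only" and "open" are said of these compounds alone.

Within the data shown here, in a functional assay on PC-3 cells (Homo sapiens) for antiproliferative activity, read by MTT assay, with a stated time of 48 h (on this read-out higher numbers stand for weaker inhibition of growth and lower numbers for stronger inhibition of growth), compound 1 (`COc1ccc(/C=C2\Cc3c(cc(OC)c(OC)c3OC)C2=O)cc1OC`) gives 7470 nM, the only true number available so far. Compound 2 (`COc1cc(/C=C2\Cc3cc(OC)c(OC)c(OC)c3C2=O)cc(OC)c1OC`) gives > 10000 nM in this assay, and this is a limit of the assay, not a number. Compound 2 therefore has no exact place on the scale, and the evidence amounts to the limit of > 10000 nM in this assay, at which 1 of the 2 values shown sits. Compound 3 (`COc1cc2c(cc1OC)C(=O)/C(=C/c1cc(OC)c(OC)c(OC)c1)C2`) differs from compound 2 in one place, with hydrogen in place of methoxy on an aromatic carbon. Among the measured compounds shown here, no measured pair shows what this kind of change does in this assay, so any expectation for its size is loose. A modest gain in growth inhibition is expected, not far beyond the usual scatter, and compound 1 at 7470 nM is the only measured reference for the level it may reach. The expected change is an at least 1.4-fold lower number from compound 2 to compound 3 (0.15 log units; that floor lies within the scatter). It also remains possible that the assay will again report only a limit. For compound 3 the estimated value is 7000 nM, with an expected range from 1500 nM to 25000 nM.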

Compound 3, concentration for 50% growth inhibition: > 10000 nM
Compound 3: no number, only a limit (the forecaster's own chance of this, stated with the estimate: 40%); at least 1.4-fold (0.15 log units) between middle value and limit.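

In this assay compound 3 gives > 10000 nM, which is a limit and not a number. Compound 2 also stands at a limit, so no step can be read between compound 2 and compound 3: the limit of > 10000 nM in this assay, at which 2 of the 3 values shown sit.

The compounds shown leave open what hydrogen in place of methoxy on an aromatic carbon does to growth inhibition in this assay.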